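Compound 3 to compound 4: tert-butoxycarbonyl for cyano

This account rests on a few compounds, and the source may have more. Where it says the series, first, only, none or still open, it means among the compounds named here.

Values in a functional assay on NALM-6 cells (Homo sapiens) for cytotoxicity, with a stated time of 72 h (a higher number here means that more compound is needed for the effect, a lower number that less compound is needed), so far:
compound 1 `C=C[C@@](C)(/C=C/c1ccc(O)cc1)CCC(O)C(C)(C)O` gives > 43400 nM as a limit
compound 2 `C=C[C@@](C)(/C=C/c1ccc(O)c(/C=C/C#N)c1)CCC=C(C)C` gives > 43400 nM as a limit
compound 3 `COc1ccc(/C=C/[C@@](C)(/C=C/c2ccc(O)c(/C=C/C#N)c2)CCC=C(C)C)cc1` gives 16500 nM as a number

Among the compounds with values here, compound 3 holds the only true number in this set, and the other two compounds sit at the limit of the assay (the limit of > 43400 nM in this assay, at which 2 of the 3 values shown sit). Compound 4 `COc1ccc(/C=C/[C@@](C)(/C=C/c2ccc(O)c(/C=C/C(=O)OC(C)(C)C)c2)CCC=C(C)C)cc1` differs from compound 3 in one group (tert-butoxycarbonyl in place of cyano on a double-bonded chain carbon bound to a double-bonded chain carbon). Here tert-butoxycarbonyl stands in place of cyano on a double-bonded chain carbon bound to a double-bonded chain carbon, so 2-cyanoethenyl becomes 2-(tert-butoxycarbonyl)ethenyl.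

Within the data shown here, only one measured step exists (an at least 2.6-fold lower number from compound 2 to compound 3 (0.42 log units; beyond the scatter)). It is 2-(4-methoxyphenyl)ethenyl in place of vinyl, at another place, with the cyano group the same on both sides. It therefore gives no size for a change at the cyano group, and no step beyond the scatter is expected in this assay in either direction. The expectation rests on compound 3 (16500 nM) as the sole anchor, so the range is kept wide. The estimated step is a 1.2-fold lower number from compound 3 to compound 4 (0.07 log units; within the scatter) and it is expected to stay within the scatter. Compound 4 is estimated at 14000 nM with 5000 nM to 43000 nM as the expected range.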

Compound 4, half-maximal effective concentration: > 43400 nM
Compound 4: only a limit was reported (the forecaster's own chance of this, stated with the estimate: 20%); at least 3.1-fold (0.49 log units) between middle value and limit.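

In this assay, tert-butoxycarbonyl in place of cyano on a double-bonded chain carbon bound to a double-bonded chain carbon gives an at least 2.6-fold higher number from compound 3 to compound 4 (0.42 log units; beyond the scatter). Within the data shown here, this is the first measured change at this place, and it shows that the group there is not interchangeable: the measurable number of compound 3 does not survive the change from 2-cyanoethenyl to 2-(tert-butoxycarbonyl)ethenyl, whereas the only earlier step concerned 2-(4-methoxyphenyl)ethenyl in place of vinyl elsewhere on the molecule. The step gives only a minimum size, because the value of compound 4 is a limit: the limit of > 43400 nM in this assay, at which 3 of the 4 values shown sit.

The compounds shown leave open whether the nitrile itself is required, or whether a smaller group on this carbon, such as a methyl ester, a carboxylic acid or a primary amide, would keep a measurable number. Also open, as far as these compounds go, is whether the same exchange has a comparable result on a core carrying vinyl in place of 2-(4-methoxyphenyl)ethenyl.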